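Replacing 2-cyanophenyl with 3-(trifluoromethyl)phenyl

A few compounds are considered here, and "the series" means these few. Any claim that something is new, unique, unknown or untested is made for them only; others in the source may bear on it.

Compound 1 `COc1cc(OC)c(-c2coc3cc(OCc4ccc(F)cc4)ccc3c2=O)cc1OC`: 3200 nM
Compound 2 `COc1cc(OC)c(-c2coc3cc(OCc4ccccc4C#N)ccc3c2=O)cc1OC`: 980 nM

In a functional assay on U-251 cells (Homo sapiens) for antiproliferative activity, read by MTT assay, with a stated time of 24 h (on this read-out lower numbers stand for stronger inhibition and higher numbers for weaker inhibition), compound 2 holds the lower of the two numbers, at 980 nM. Compound 3 `COc1cc(OC)c(-c2coc3cc(OCc4cccc(C(F)(F)F)c4)ccc3c2=O)cc1OC` is still unmeasured and differs from it as follows: 3-(trifluoromethyl)phenyl in place of 2-cyanophenyl on a saturated chain carbon bound to an oxygen on an aromatic ring. In words, 3-(trifluoromethyl)phenyl stands in place of 2-cyanophenyl on a saturated chain carbon bound to an oxygen on an aromatic ring.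

Going by the values given here, only one measured step bears on this place: a 3.3-fold lower number from compound 1 to compound 2 (0.51 log units; beyond the scatter). It is modest but beyond the scatter, and 2-cyanophenyl sits on its lower side. That step involved 4-fluorophenyl, so the entering group itself has no measured reading. With 2-cyanophenyl leaving, a modest rise is expected, given the lower number of compound 2 at 980 nM. The expected size is a 1.8-fold higher number from compound 2 to compound 3 (0.26 log units; within the scatter). For compound 3 the estimated value is 1800 nM, with an expected range of 700 nM to 4500 nM.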

Compound 3, half-maximal inhibitory concentration: > 10000 nM
Compound 3: no number, only a limit (the forecaster's own chance of this, stated with the estimate: 3%); middle value at least 5.5-fold (0.74 log units) away from the limit.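

In this assay, compound 3 gives no number, only a limit of the assay: the limit of > 10000 nM in this assay, at which 1 of the 3 values shown sits. At this place, on a saturated chain carbon bound to an oxygen on an aromatic ring, 3-(trifluoromethyl)phenyl gives an at least 10-fold higher number from compound 2 to compound 3 (1.00 log units; beyond the scatter), and in place of 4-fluorophenyl it gives an at least 3.1-fold higher number from compound 1 to compound 3 (0.49 log units; beyond the scatter). Not every substituted phenyl group is therefore accommodated equally here, and across the three compounds the order runs 2-cyanophenyl, 4-fluorophenyl, 3-(trifluoromethyl)phenyl, from lowest number to highest, with each step beyond the scatter.

Going by these compounds, whether a 3-cyanophenyl or a 2-(trifluoromethyl)phenyl group would read closer to compound 2 or to compound 3 stays open, and with it whether the substituent or its place on the ring sets the result. The reading of a plain phenyl or a pyridyl group at this place is open as well.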